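The source may report more compounds than this note shows. Statements on the series, on what has been measured and on what is new or still open speak of the compounds shown alone.

Working notes on the series. Compound 1 `COC/C1=C/C[C@](C)(CCC=C(C)C)/C=C/[C@@H](OC(=O)C=C(C)C)[C@](C)(O)/C=C/C1=O` gives 3950 nM in a functional assay on A549 cells (Homo sapiens) for antiproliferative activity, read by MTT assay, with a stated time of 48 h (a higher number here means a weaker inhibitor, a lower number a stronger inhibitor), and stands as the higher of the two numbers measured there. The nearest number is that of compound 3 `CC(C)=CCC[C@]1(C)/C=C/[C@@H](OC(=O)C=C(C)C)[C@](C)(O)/C=C/C(O)/C(C=O)=C\C1`, which gives 570 nM in this assay, a gap beyond the usual scatter. Compound 2 `CC(C)=CCC[C@]1(C)/C=C/[C@@H](OC(=O)C=C(C)C)[C@](C)(O)/C=C/[C@H](O)/C(CO)=C\C1` gives only a limit, > 40000 nM, in this assay; this is the limit of > 40000 nM in this assay, at which 1 of the 3 values shown sits. Compound 4 `CC(C)=CCC[C@]1(C)/C=C/[C@@H](OC(=O)C=C(C)C)[C@](C)(O)/C=C/C(=O)/C(C(=O)N(C)C)=C\C1` has not yet been measured. Relative to compound 1 it differs by dimethylcarbamoyl in place of methoxymethyl on a double-bonded ring carbon. No step between measured compounds is known for this kind of change, so nothing shown fixes its direction. For compound 4 the expected step in this assay is a 1.3-fold lower number from compound 1 to compound 4 (0.12 log units; within the scatter), not beyond the scatter. The estimate for compound 4 is 3000 nM, expected between 700 nM and 13000 nM.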

Compound 4, half-maximal inhibitory concentration: 2700 nM
The estimate for compound 4 lay 1.1-fold (0.05 log units) above the measured number; the measured number falls inside the stated range.
By their numbers in this assay, from the lowest: compound 3; then compounds 4 and 1 (each within the scatter of the next). At a limit, above all of these: compound 2.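

Dimethylcarbamoyl in place of methoxymethyl on the double-bonded ring carbon gives a 1.5-fold lower number from compound 1 to compound 4 (0.17 log units; within the scatter) in this assay. For the compounds shown here, this is the first step measured at this position, and it shows that the two groups cannot be told apart here, although dimethylcarbamoyl has more heavy atoms. Nothing measured here bears on the reason for this step.

Going by these compounds, whether a carboxylic acid or a primary amine on this ring carbon would give a step beyond the scatter remains open. Compound 2 and compound 3 differ from compound 1 in more than one place, so neither isolates this position.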